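The compounds below may be only part of what the source reports. "The series", "measured", "known", "first", "only" and "open" are said of these compounds alone.

Measured so far in a functional assay on MCF7 cells (Homo sapiens) for inhibition, read by sulforhodamine B assay, with a stated time of 72 h; a lower number here means a stronger inhibitor, a higher number a weaker inhibitor:

compound 1 `COc1cc(OC)c(C(=O)/C=C/c2cn(-c3ccccc3)nc2-c2ccsc2)c(OC)c1`: 2700 nM
compound 2 `COc1ccc(C(=O)/C=C/c2cn(-c3ccccc3)nc2-c2ccsc2)c(OC)c1`: 9000 nM
compound 3 `COc1ccc(C(=O)/C=C/c2cn(-c3ccccc3)nc2-c2cccnc2)c(OC)c1OC`: 1400 nM

Compound 1 and compound 2 share a core and differ by hydrogen in place of methoxy on an aromatic carbon; in this assay this gave a 3.3-fold higher number from compound 1 to compound 2 (0.52 log units; beyond the scatter). Compound 3 carries a different core; how the core of compound 3 differs from that of compound 1 is not broken down here. The values of compound 3 and compound 1 lie within the scatter of each other, while compound 2 stands beyond the scatter from both.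

Compound 4 `COc1ccc(C(=O)/C=C/c2cn(-c3ccccc3)nc2-c2cccnc2)cc1OC` differs from compound 3 by hydrogen in place of methoxy on an aromatic carbon. The surroundings are not identical to those of the earlier pair: in compound 1 the leaving methoxy is meta to two methoxy groups, whereas in compound 3 it is ortho to a methoxy group and meta to a methoxy group, so the change is of the same kind, not the same. The expectation for compound 4 is nevertheless a step of similar size, a 3.2-fold higher number from compound 3 to compound 4 (0.51 log units; beyond the scatter), resting on the step seen in compound 1 to compound 2, a 3.3-fold higher number from compound 1 to compound 2 (0.52 log units; beyond the scatter). For compound 4 the estimate in this assay is 4500 nM, expected between 1800 nM and 12000 nM.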

Compound 4, half-maximal inhibitory concentration: 1700 nM
For compound 4 the middle estimate is 2.6-fold (0.42 log units) above the measured one, outside the stated range (below it).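

In this assay, hydrogen in place of methoxy on an aromatic carbon does not carry the same step from one core to the other: the same change on two cores in this assay, a 3.3-fold higher number (0.52 log units; beyond the scatter) from compound 1 to compound 2 and a 1.2-fold higher number (0.08 log units; within the scatter) from compound 3 to compound 4, 2.7-fold (0.44 log units) apart, beyond the scatter of two such steps. On the core of compound 3, the replacement gives a 1.2-fold higher number from compound 3 to compound 4 (0.08 log units; within the scatter), so this methoxy can be lost there without a readable change, and the larger step on the core of compound 1 is no guide to this core. This does not show what sets the two steps apart: the pairs differ in the core and also in how the remaining methoxy groups are placed, and two pairs cannot separate these or give a rule for the series.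

Still open, as far as these compounds go, is whether the step on a further core would resemble either of these two, or whether it depends on the placing of the methoxy groups. Also open, from the compounds shown here alone, is how a hydroxyl group, an amine or a longer alkoxy chain at this aromatic carbon would compare with methoxy and hydrogen.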